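This account rests on a few compounds, and the source may have more. Where it says the series, first, only, none or still open, it means among the compounds named here.

Compound 1 `Cc1cc2nc(-c3cn(-c4ccccc4)nc3-c3ccccc3)[nH]c2cc1C` and compound 3 `Cc1cc2nc(-c3cn(-c4ccccc4)nc3-c3ccc(Cl)cc3)[nH]c2cc1C` share one core, while compound 2 `Clc1ccc(-c2nn(-c3ccccc3)cc2-c2nc3cc(Cl)ccc3[nH]2)cc1` is built on another; how the two cores differ is not broken down here. In a functional assay on A549 cells (Homo sapiens) for antiproliferative activity, read by MTT assay, with a stated time of 48 h (on this read-out higher numbers stand for weaker inhibition and lower numbers for stronger inhibition), compound 1 gives 14500 nM and compound 3 gives 17700 nM, so the change chloro in place of hydrogen on an aromatic carbon made a 1.2-fold higher number from compound 1 to compound 3 (0.09 log units; within the scatter). Compound 2 gives 1340 nM in this assay, the lowest of the three numbers and beyond the scatter from both of the others.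

Compound 4 `Clc1ccc(-c2nn(-c3ccccc3)cc2-c2nc3cc(Cl)c(Cl)cc3[nH]2)cc1` has not yet been measured. It differs from compound 2 by chloro in place of hydrogen on an aromatic carbon, the same kind of change as that seen between compound 1 and compound 3, but at a different place: here the chloro enters on a ring that is part of a fused or bridged system of two rings, ortho to a chloro group, meta to a fused ring and para to a fused ring, whereas in compound 3 it entered para to a large group. The first such change gave a 1.2-fold higher number from compound 1 to compound 3 (0.09 log units; within the scatter). On that basis the step to compound 4 is expected to be small, a 1.1-fold higher number from compound 2 to compound 4 (0.05 log units; within the scatter). Compound 4 is therefore estimated to give 1500 nM in this assay, most likely between 500 nM and 4500 nM.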

Compound 4, half-maximal inhibitory concentration: 19100 nM
Estimate against measurement, compound 4: 13-fold (1.10 log units) below; measured number outside the range, above it.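

In this assay, the chloro that enters on the fused ring of compound 2, ortho to a chloro group, makes a large difference, a 14-fold higher number from compound 2 to compound 4 (1.15 log units; beyond the scatter). The same kind of change therefore did not carry over with the same size from one core to the other: the same change on two cores in this assay, a 1.2-fold higher number (0.09 log units; within the scatter) from compound 1 to compound 3 and a 14-fold higher number (1.15 log units; beyond the scatter) from compound 2 to compound 4, 12-fold (1.07 log units) apart, beyond the scatter of two such steps

What this does not show is why the two steps differ: they differ in both the core and the place of the chloro, so these compounds cannot separate the two, and a pair of steps sets no rule for any other core. The compounds shown leave open whether a different group at the place taken by the new chloro, such as a methoxy or an amine, would give a step as large as the one seen with chloro. They also leave open whether the size of the step depends on the chloro group already on that ring.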